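A Third Aryl Amine Variant in a Weak Cell Series

This account rests on a few compounds, and the source may have more. Where it says the series, first, only, none or still open, it means among the compounds named here.

Measured so far in a functional assay on MGC-803 cells (Homo sapiens) for inhibition, read by MTT assay, with a stated time of 72 h; a higher number here means a weaker inhibitor, a lower number a stronger inhibitor:
Compound 1 `C=CC(=O)Nc1cccc(NC(=O)CSc2nc(Nc3ccccc3Cl)c3ccccc3n2)c1`: 20700 nM
Compound 2 `C=CC(=O)Nc1cccc(NC(=O)CSc2nc(Nc3ccc(C(F)(F)F)cc3)c3ccccc3n2)c1`: 12100 nM

Compound 2 holds the lower of the two numbers, yet the step of a 1.7-fold lower number from compound 1 to compound 2 (0.23 log units; within the scatter) lies within the usual scatter, so the two compounds cannot be told apart on potency. Compound 3 `C=CC(=O)Nc1cccc(NC(=O)CSc2nc(Nc3cc(OC)c(OC)c(OC)c3)c3ccccc3n2)c1` changes the same position again: 3,4,5-trimethoxyphenyl in place of 4-(trifluoromethyl)phenyl on a nitrogen on an aromatic ring. Among the measured compounds shown here, only one measured step bears on this change, the swap of one substituted phenyl for another on that nitrogen, which gave a 1.7-fold lower number from compound 1 to compound 2 (0.23 log units; within the scatter); no measured compound carries methoxy groups at this place. On that basis the expected step is a 1.0-fold lower number from compound 2 to compound 3 (0.00 log units; within the scatter), with no movement beyond the scatter foreseen. Compound 3 is therefore estimated at 12000 nM in this assay, with an expected range from 4000 nM to 40000 nM.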

Compound 3, half-maximal inhibitory concentration: > 50000 nM
Compound 3 gave a limit, no number; the forecaster's own chance of this, stated with the estimate: 10%; middle value at least 4.1-fold (0.61 log units) from the limit.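

In this assay compound 3 gives > 50000 nM as a limit of the assay, not a number. The earlier swap on this nitrogen stayed within the scatter, so it could not show that the group here matters, but an at least 4.1-fold higher number from compound 2 to compound 3 (0.61 log units; beyond the scatter) and an at least 2.4-fold higher number from compound 1 to compound 3 (0.38 log units; beyond the scatter) both lie beyond it. The position is therefore not indifferent to the aryl group it carries, and 3,4,5-trimethoxyphenyl is the one group shown that separates from the others, with its reading stopping at the assay's ceiling: the limit of > 50000 nM in this assay, at which 1 of the 3 values shown sits.

On these data alone, it remains open how far compound 3 truly lies from compound 1 and compound 2. As far as these compounds go, it is also open whether a single methoxy group on the phenyl ring, or a morpholine or a carboxylic acid there, would reach the same limit.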